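From benzamido back to an ester on the ring

The compounds below may be only part of what the source reports. "The series", "measured", "known", "first", "only" and "open" are said of these compounds alone.

Within the data shown here, in an ADME assay on Vero cells (Chlorocebus sabaeus) for cytotoxicity, read by MTT assay, with a stated time of 48 h (on this read-out higher numbers stand for weaker inhibition and lower numbers for stronger inhibition), compound 3 `O=C(NC1CCC(CN2CCN(c3cc(=O)c4cc(C(F)(F)F)cc([N+](=O)[O-])c4s3)CC2)CC1)c1ccccc1` gives 44.3 ug/mL as the only true number so far. Compound 1 `CC(C)C(=O)OC1CCC(CN2CCN(c3cc(=O)c4cc(C(F)(F)F)cc([N+](=O)[O-])c4s3)CC2)CC1` gives > 64 ug/mL as a limit of the assay and not a number. Compound 2 `O=C(OC1CCC(CN2CCN(c3cc(=O)c4cc(C(F)(F)F)cc([N+](=O)[O-])c4s3)CC2)CC1)c1cccc(C(F)(F)F)c1` gives > 64 ug/mL as a limit too. The picture therefore rests largely on the limit of > 64 ug/mL in this assay, at which 2 of the 3 values shown sit, and offers little fine detail.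

Compound 4 `Cc1ccc(C(=O)OC2CCC(CN3CCN(c4cc(=O)c5cc(C(F)(F)F)cc([N+](=O)[O-])c5s4)CC3)CC2)cc1` keeps the shared core and carries ((4-methylphenyl)carbonyl)oxy in place of benzamido on a saturated ring carbon, a change counted as ((4-methylphenyl)carbonyl)oxy in place of benzamido on a saturated ring carbon and untested so far.

The nearest measured step is an at least 1.4-fold lower number from compound 1 to compound 3 (0.15 log units; that floor lies within the scatter) for the swap of an ester group for benzamido, and it runs the opposite way. Its size is only a floor, and that floor lies within the scatter. The other step, a step that the two limits leave unreadable from compound 1 to compound 2 on replacing isopropyl with 3-(trifluoromethyl)phenyl on a carbonyl carbon, sets no size, yet both esters remain at the limit. Compound 4 is also an ester, so a return toward that limit seems likely.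

The expectation is a 1.6-fold higher number from compound 3 to compound 4 (0.20 log units; within the scatter) as a modest move toward weaker inhibition, not clearly beyond the scatter. In this assay the estimate for compound 4 is 70 ug/mL with an expected range from 40 ug/mL to 128 ug/mL and a good chance of ending at the limit.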

Compound 4, half-maximal inhibitory concentration: > 64 ug/mL
Compound 4 ended at the assay's limit (the forecaster's own chance of this, stated with the estimate: 65%); the middle value is on the limit's open side.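

In this assay, the swap of benzamido for ((4-methylphenyl)carbonyl)oxy on the saturated ring carbon now has a direct pair, giving an at least 1.4-fold higher number from compound 3 to compound 4 (0.15 log units; that floor lies within the scatter), so this change has a measured floor, but that floor cannot separate the two compounds. Compound 4 gives > 64 ug/mL, which is a limit of the assay and not a number. The steps among compounds 1, 2 and 4 cannot be read, but a third carbonyl partner, 4-methylphenyl after isopropyl and 3-(trifluoromethyl)phenyl, also leaves an ester at this limit, while compound 3, the only amide, goes against that pattern with the only true number, and the comparison remains coarse: the limit of > 64 ug/mL in this assay, at which 3 of the 4 values shown sit.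

From the compounds shown here alone, how far any of the three esters lies past the limit stays open, so nothing can be said about their order or about whether the groups on their carbonyl carbon matter at all. Also open, going by these compounds, is whether the link itself carries the difference, a question that an amide bearing 4-methylphenyl could address directly, while a free amine or hydroxyl on the same ring carbon would show what happens with no carbonyl group there.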